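The source may hold more compounds than are shown below. What is called first, only, known or untested is meant among the compounds shown, and "the series" means these compounds.

Three compounds share one core and differ only in the group carried on the aromatic ring. Compound 1 `CC(C)Oc1ccccc1OC(C)C1=NCCN1` gives 0.7 in an assay on CHO cells with Alpha-2C adrenergic receptor (Homo sapiens) as the target; a higher number here means a larger maximal response, a lower number a smaller maximal response. Compound 2 `C=COc1ccccc1OC(C)C1=NCCN1` gives 0.48, and compound 3 `Cc1cccc(C)c1OC(C)C1=NCCN1` gives 0.82. Compound 2 thus stands lowest of the three, with compound 1 the nearest and compound 3 the furthest. Within the data shown here, the one step measured so far, vinyl in place of isopropyl on an oxygen on an aromatic ring, is a number 0.22 lower from compound 1 to compound 2 (beyond the scatter).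

Compound 4 `CCc1ccccc1OC(C)C1=NCCN1` has not yet been measured. It differs from compound 2 as follows: ethyl in place of vinyloxy on an aromatic carbon. Among the measured compounds shown here, no measured step matches this change, so the expectation rests on what the three numbers show: the oxygen-linked groups of compound 1 and compound 2 sit lower than the methyl groups of compound 3, and the ethyl of compound 4 is likewise carbon only. The step from compound 2 to compound 4 is therefore expected to be upward, about a number 0.27 higher from compound 2 to compound 4 (beyond the scatter), beyond the scatter. Compound 4 is expected to give about 0.75, within a range from 0.55 to 0.95.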

Compound 4, intrinsic activity: the largest response reached, as a fraction of the reference agonist's: 0.6
Beside the measured number, compound 4's estimate is 0.15 above it; the measured number falls inside the stated range.
By their numbers in this assay, from the lowest: compound 2; then compounds 4 and 1 (each within the scatter of the next); then compound 3.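

Ethyl in place of vinyloxy on this aromatic carbon gives a number 0.12 higher from compound 2 to compound 4 (beyond the scatter) in this assay, so an oxygen attached at this place is not required for a sizeable maximal response. Ethyl in place of isopropoxy gives a number 0.10 lower from compound 1 to compound 4 (within the scatter), which means the two oxygen-linked groups do not behave alike when exchanged for ethyl: only the vinyloxy exchange can be told apart from the scatter. No separate measurement is available to explain this difference.

The compounds shown leave open whether the low value of compound 2 follows from its oxygen, its double bond or both, and ethoxy, which keeps the oxygen without the double bond, would separate these. From the compounds shown here alone, how far this place tolerates other groups, such as an amine or a longer chain like butyl, also remains open.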